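A Chlorine Added to the Benzylsulfanyl Arm

The source may report more compounds than this note shows. Statements on the series, on what has been measured and on what is new or still open speak of the compounds shown alone.

Of the compounds shown here, three from one series have been measured so far, and a fourth awaits its number. Compound 1 `COc1ccc(C2N=C(SCc3ccccc3)NC(C)=C2C(=O)Nc2ccc(F)cc2)cc1OC` heads the first pair, and in a functional assay on the whole organism (artery, strain albino) with Rattus norvegicus as the target, with a stated time of 360 min, at a dose of 10 mg/kg by the oral route (on this read-out higher numbers stand for more inhibition at the one dose given (going by the name of the read-out) and lower numbers for less inhibition), compound 1 gives 3.6%. Compound 2 `COc1ccc(C2N=C(SCc3ccc(Cl)cc3)NC(C)=C2C(=O)Nc2ccc(F)cc2)cc1OC` differs from it by chloro in place of hydrogen on an aromatic carbon; in this assay compound 2 gives 37.1%, and the step of a number 33.5 percentage points higher from compound 1 to compound 2 (beyond the scatter). Compound 3 `COc1ccc(C2N=C(SCc3ccccc3)NC(C)=C2C(=O)Nc2ccc(Br)cc2)cc1` rests on a different core; the difference between its core and the core of compound 1 is not broken down here. In this assay compound 3 gives 18.6%, which sets it between the other two.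

Compound 4 `COc1ccc(C2N=C(SCc3ccccc3Cl)NC(C)=C2C(=O)Nc2ccc(Br)cc2)cc1` arises from compound 3 by chloro in place of hydrogen on an aromatic carbon. For the measured compounds named here, this is the same kind of change as the one from compound 1 to compound 2, but not the same: in the measured pair the chloro sits para to a large group, whereas in compound 4 it sits ortho to a large group. Going by the values given here, the one measured instance of this kind of change, a number 33.5 percentage points higher from compound 1 to compound 2 (beyond the scatter), is large. With both the place of the chloro and the core differing from the measured pair, the expected step in this assay is a number 16.4 percentage points higher from compound 3 to compound 4 (beyond the scatter), in the same direction but smaller. Compound 4 is estimated at 35%, with a range from 10% to 60%, an expectation resting on a number 33.5 percentage points higher from compound 1 to compound 2 (beyond the scatter).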

Compound 4, a percentage reported as inhibition, in the whole organism at one dose (the size of the read-out at that dose, not a potency): 20.6%
Estimate against measurement, compound 4: 14.4 percentage points above; low and high end bracket the measured number.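

In this assay, the chloro that mattered so much on the core of compound 1 does not repeat its effect on the core of compound 3: the step is a number 2 percentage points higher from compound 3 to compound 4 (within the scatter). Set side by side, the two results show that this kind of change does not carry a fixed gain from one core to the other in this series: the same change on two cores in this assay, a number 33.5 percentage points higher (beyond the scatter) from compound 1 to compound 2 and a number 2 percentage points higher (within the scatter) from compound 3 to compound 4, 31.5 percentage points apart, beyond the scatter of two such steps What this does not show is whether the core or the place of the chloro separates the two results, since the chloro in compound 4 sits ortho to a large group, the chloro in compound 2 sits elsewhere on the ring, and the two pairs differ in both respects at once.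

The compounds shown leave open what 2-chlorobenzyl would do on the core of compound 1, and what a chloro placed as in compound 2 would do on the core of compound 3, and only these two pairings could pull the two explanations apart. They also leave open how the benzylsulfanyl arm would respond to an amine or a carboxylic acid on its ring, or to a longer chain in place of benzyl.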